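This account rests on a few compounds, and the source may have more. Where it says the series, first, only, none or still open, it means among the compounds named here.

Of the compounds shown here, three have been measured in a functional assay on SK-BR-3 cells (Homo sapiens) for antiproliferative activity, read by MTT assay, with a stated time of 72 h; on this read-out higher numbers stand for weaker inhibition and lower numbers for stronger inhibition. Compound 1 `CCN1CCN(c2cc(C)c3cc(NC(=O)c4ccccc4F)ccc3n2)CC1` gives 38100 nM, compound 2 `Cc1cc(NCCN(C)C)nc2ccc(NC(=O)c3ccc(Cl)c(Cl)c3)cc12` gives 6670 nM, and compound 3 `CCc1ccc(C(=O)Nc2ccc3nc(N4CCN(CC)CC4)cc(C)c3c2)cc1` gives 9850 nM. For the measured compounds named here, compound 3 stands second highest of the three numbers; its nearest neighbour is compound 2, within the scatter, while the only single-point step, a 3.9-fold lower number from compound 1 to compound 3 (0.59 log units; beyond the scatter), replaced 2-fluorophenyl with 4-ethylphenyl on a carbonyl carbon. Compound 4 `CCN1CCN(c2cc(C)c3cc(NC(=O)c4ccc(OC)cc4)ccc3n2)CC1` differs from compound 3 by methoxy in place of ethyl on an aromatic carbon. Going by the values given here, no measured step exchanges one group for another on an aromatic carbon para to a large group, so there is no direct guide; the closeness of compound 3 to compound 2 suggests little movement. The expected step is therefore a 1.0-fold higher number from compound 3 to compound 4 (0.01 log units; within the scatter), none beyond the scatter. Compound 4 is estimated at 10000 nM, between 4000 nM and 25000 nM.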

Compound 4, half-maximal inhibitory concentration: 9000 nM
For compound 4 the middle estimate is 1.1-fold (0.05 log units) above the measured one; low and high end bracket the measured number.
By their numbers in this assay, from the lowest: compounds 2, 4 and 3 (each within the scatter of the next); then compound 1.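

In this assay the change from ethyl to methoxy on an aromatic carbon para to a large group gives a 1.1-fold lower number from compound 3 to compound 4 (0.04 log units; within the scatter) and so no real shift, even though methoxy brings a hydrogen-bond acceptor that ethyl lacks. Against 2-fluorophenyl, 4-methoxyphenyl gives a 4.2-fold lower number from compound 1 to compound 4 (0.63 log units; beyond the scatter) and so matches what 4-ethylphenyl did, which means this drop is no longer tied to a single group. No measurement here gives a reason for either step.

Still open, going by these compounds, is whether an amine, a carboxylic acid or a longer chain in that place would move the number, and whether any group is needed there at all.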